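Shrinking the amine ring: compound 1 to compound 4

This account rests on a few compounds, and the source may have more. Where it says the series, first, only, none or still open, it means among the compounds named here.

Measured so far:
Compound 1 `c1ccc(COc2ccc(OCCOCCNC3CCCC3)cc2)cc1` — 24800 nM
Compound 2 `Clc1ccc(COc2ccc(OCCOCCNC3CCCC3)cc2)cc1` — 7670 nM
Compound 3 `COC(=O)c1ccc(COc2ccc(OCCOCCNC3CCCC3)cc2)cc1` — 6990 nM

In a functional assay on SK-OV-3 cells (Homo sapiens) for inhibition, read by CCK-8 assay, with a stated time of 70 h (a higher number here means a weaker inhibitor, a lower number a stronger inhibitor), compound 1 gives 24800 nM, the highest number of the three. The nearest value lies a step away, a 3.2-fold lower number from compound 1 to compound 2 (0.51 log units; beyond the scatter), and the furthest a 3.5-fold lower number from compound 1 to compound 3 (0.55 log units; beyond the scatter); the step of a 1.1-fold lower number from compound 2 to compound 3 (0.04 log units; within the scatter) is within the scatter. Both measured steps alter an aromatic carbon of the benzyl group and leave the amine untouched.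

Compound 4 `c1ccc(COc2ccc(OCCOCCNC3CC3)cc2)cc1` differs from compound 1 by cyclopropyl in place of cyclopentyl on an amine nitrogen. Going by the values given here, no measured step touches this amine nitrogen, so nothing recorded here bears on it directly. Without such guidance, compound 4 is expected to give a number close to that of compound 1, a 1.2-fold higher number from compound 1 to compound 4 (0.08 log units; within the scatter), within the scatter. The estimate for compound 4 in this assay is 30000 nM, ranging from 10000 nM to 90000 nM.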

Compound 4, half-maximal inhibitory concentration: 47200 nM
Compound 4: the middle estimate sits 1.6-fold (0.20 log units) below what was measured; the measured number falls inside the stated range.
By their numbers in this assay, from the lowest: compounds 3 and 2 (each within the scatter of the next); then compounds 1 and 4 (each within the scatter of the next).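

In this assay, going by these compounds alone, the first step at the amine nitrogen, cyclopropyl in place of cyclopentyl, gives a 1.9-fold higher number from compound 1 to compound 4 (0.28 log units; within the scatter), so this change separates compound 4 from compound 1 by no more than repeat measurements would. Unlike the chloro and methoxycarbonyl steps on the benzyl group, this step therefore shows no measurable effect. Nothing available here offers an explanation for this result. Still open, from the compounds shown here alone, is how a cyclohexyl ring or an open-chain isopropyl group on this nitrogen would read, and whether chloro on the benzyl group would give the same step alongside cyclopropyl.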